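Exchanging the aryl group on the saturated ring carbon

The compounds below may be only part of what the source reports. "The series", "measured", "known", "first", "only" and "open" are said of these compounds alone.

This account follows three measured compounds and one still to be measured, all sharing the same core. In a physicochemical assay for lipophilicity, in phosphate buffer, measured as octanol-water partition, with a stated time of 24 h (on this read-out higher numbers stand for higher lipophilicity and lower numbers for lower lipophilicity), compound 1 `O=C(CN1C(=O)c2ccccc2C1=O)NN1C(=O)CSC1/C=C/c1ccccc1` gives 3.65. Compound 2 `O=C(CN1C(=O)c2ccccc2C1=O)NN1C(=O)CSC1c1cccnc1` gives 1.25 in this assay, and compound 3 `O=C(CN1C(=O)c2ccccc2C1=O)NN1C(=O)CSC1c1cccs1` gives 2.15. Compound 2 stands lowest of the three numbers: the nearest value is that of compound 3, and the step of a number 0.90 log units higher from compound 2 to compound 3 (beyond the scatter) lies beyond the scatter, while the step of a number 2.40 log units lower from compound 1 to compound 2 (beyond the scatter) is the largest among the measured compounds.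

Compound 4 `COc1ccc(C2SCC(=O)N2NC(=O)CN2C(=O)c3ccccc3C2=O)cc1OC` differs from compound 2 in one place: 3,4-dimethoxyphenyl in place of pyridin-3-yl on a saturated ring carbon. The step that bears most on this change is a number 0.90 log units higher from compound 2 to compound 3 (beyond the scatter), where one aromatic ring on that saturated ring carbon replaced another and gave a modest rise. The step of a number 2.40 log units lower from compound 1 to compound 2 (beyond the scatter) shows that such exchanges at this position can move the read-out by a large amount. A six-membered ring of carbon only with two methoxy groups enters in place of a ring holding a nitrogen, so a rise beyond the scatter is expected for compound 4, estimated as a number 1.15 log units higher from compound 2 to compound 4 (beyond the scatter). Compound 4 is therefore expected to give about 2.4 in this assay, within a range from 1.8 to 3.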

Compound 4, partition coefficient: 2.78
Estimate against measurement, compound 4: 0.38 log units below; low and high end bracket the measured number.
By their numbers in this assay, from the lowest: compound 2; then compound 3; then compound 4; then compound 1.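

For the compounds shown here, with compound 4, the exchange on the saturated ring carbon gains a fourth point in this assay, and the 3,4-dimethoxyphenyl group falls inside the span of the earlier compounds rather than at either end: the record gives a number 1.53 log units higher from compound 2 to compound 4 (beyond the scatter) and a number 0.63 log units higher from compound 3 to compound 4 (beyond the scatter) but also a number 0.87 log units lower from compound 1 to compound 4 (beyond the scatter) at this position. Among the three compounds with an aromatic ring directly on this carbon, the order now runs from pyridin-3-yl through thiophen-2-yl to 3,4-dimethoxyphenyl, with every step beyond the scatter, while the 2-phenylethenyl group of compound 1 still stands highest of the four. No separate finding is at hand that would explain this order.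

Going by these compounds, it stays open how much of the step from pyridin-3-yl goes with the carbon-only ring and how much with the two methoxy groups, a question that an unsubstituted phenyl ring or a ring with a single methoxy group would address. Also open, on these data alone, is where a carboxylic acid or an amine on that ring would fall in this order.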